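This account rests on a few compounds, and the source may have more. Where it says the series, first, only, none or still open, it means among the compounds named here.

Of the compounds shown here, two sharing one core have been measured in a functional assay on the whole organism with Rattus norvegicus as the target; a lower number here means that less compound is needed, a higher number that more compound is needed for the effect. Compound 1, `CCOC(=O)C(=O)Nc1nc(-c2ccc([N+](=O)[O-])cc2)cs1`, gives in this assay no number but only a limit, > 100 mg/kg. Compound 2, `CCCC(=O)Nc1ccc(-c2csc(NC(=O)C(=O)OCC)n2)cc1`, gives in this assay likewise only a limit, > 10 mg/kg. Among the measured compounds shown here, the single step between them, a step that the two limits leave unreadable from compound 1 to compound 2, cannot be read; what stands behind it is the limit of > 100 mg/kg in this assay, at which 1 of the 2 values shown sits, and (the limit of > 10 mg/kg in this assay, at which 1 of the 2 values shown sits). Compound 2 thus stands at a limit and at no definite point on the numbers shown. Compound 3, `CCOC(=O)C(=O)Nc1nc(-c2ccc(C(=O)OCC)cc2)cs1`, differs from compound 2 by ethoxycarbonyl in place of (propylcarbonyl)amino on an aromatic carbon. For the measured compounds named here, no measured step bears on this change, the only step on record being unreadable, so no size or direction of step beyond the scatter can be expected in this assay. The step from compound 2 to compound 3 is expected to be a step that the limit leaves unreadable from compound 2 to compound 3. For compound 3 the estimate in this assay is 30 mg/kg, with a range from 10 mg/kg to 100 mg/kg, and it is expected that the assay may again report only a limit.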

Compound 3, dose for half-maximal effect: > 10 mg/kg
Compound 3: a limit, no number (the forecaster's own chance of this, stated with the estimate: 70%); the middle value lies beyond the limit too.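

In this assay compound 3 gives only a limit, > 10 mg/kg. None of the steps among compound 1, compound 2 and compound 3 can be read, in size or in direction. The compounds shown leave open where any of the three stands in this assay, and whether nitro, (propylcarbonyl)amino or ethoxycarbonyl on the aromatic carbon changes the dose needed.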